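Swapping Ethynyl for Methylsulfanyl on a Phenol Core

The source may report more compounds than this note shows. Statements on the series, on what has been measured and on what is new or still open speak of the compounds shown alone.

Compound 2 `C#Cc1cc(C(=O)N2CS(=O)(=O)c3ccccc32)cc(C#N)c1O` gives the lowest of the two numbers seen so far: in an assay on tissue (RPTEC cells) for inhibition of solute carrier family 22 member 12 (Homo sapiens), read by scintillation counting, with stated times of 15 min and 2 h (on this read-out higher numbers stand for weaker inhibition and lower numbers for stronger inhibition), compound 2 gives 3200 nM. For the measured compounds named here, compound 1 `N#Cc1cc(C(=O)N2CS(=O)(=O)c3ccccc32)cc(C2CC2)c1O` gives 19200 nM, and the single measured step, a 6.0-fold lower number from compound 1 to compound 2 (0.78 log units; beyond the scatter), concerns a different swap on the same aromatic carbon. Compound 3 `CSc1cc(C(=O)N2CS(=O)(=O)c3ccccc32)cc(C#N)c1O` differs from compound 2 by methylsulfanyl in place of ethynyl on an aromatic carbon. Going by the values given here, no measured step tests methylsulfanyl in this place, so the direction is open and only a modest shift, if any, is anticipated. Compound 3 is expected near 5000 nM, between 1500 nM and 16000 nM, an estimated step of a 1.6-fold higher number from compound 2 to compound 3 (0.19 log units; within the scatter).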

Compound 3, half-maximal inhibitory concentration: 7100 nM
Estimate against measurement, compound 3: 1.4-fold (0.15 log units) below, and the stated range covers the measured number.
By their numbers in this assay, from the lowest: compound 2; then compound 3; then compound 1.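

Methylsulfanyl gives a third reading at this aromatic carbon, ortho to a hydroxy group: in this assay, the change shows a 2.2-fold higher number from compound 2 to compound 3 (0.35 log units; beyond the scatter), while the comparison with cyclopropyl shows a 2.7-fold lower number from compound 1 to compound 3 (0.43 log units; beyond the scatter). Methylsulfanyl therefore sits between the other two groups, with ethynyl giving the strongest inhibition of the three and cyclopropyl the weakest. Nothing available explains this order. On these data alone, how an amine, a carboxylic acid or a longer chain would rank at this carbon remains open. So does whether the same order would hold if the cyano group were replaced.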